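This account rests on a few compounds, and the source may have more. Where it says the series, first, only, none or still open, it means among the compounds named here.

Three compounds share an aryl pyrazole urea core and were measured in a functional assay on PC-3 cells (Homo sapiens) for inhibition, read by sulforhodamine B assay, with a stated time of 48 h; on this read-out higher numbers stand for weaker inhibition of growth and lower numbers for stronger inhibition of growth. Compound 2 `COc1cc(-c2nn(-c3cccc(NC(=O)Nc4cccc(C(F)(F)F)c4)c3)cc2-c2ccncc2)ccc1Cl` gives 2510 nM. Compound 1 `O=C(Nc1cccc(-n2cc(-c3ccncc3)c(-c3ccc(Cl)c(O)c3)n2)c1)Nc1cccc(C(F)(F)F)c1` gives 22500 nM; it differs from compound 2 by hydrogen in place of methyl on an oxygen on an aromatic ring, and the step was a 9.0-fold higher number from compound 2 to compound 1 (0.95 log units; beyond the scatter). Compound 3 `COc1cc(-c2nn(-c3cccc(NC(=O)Nc4ccc(Cl)c(C(F)(F)F)c4)c3)cc2-c2ccncc2)ccc1Cl` gives 2450 nM; its core differs from that of compound 2 by chloro in place of hydrogen on an aromatic carbon, and the step was a 1.0-fold lower number from compound 2 to compound 3 (0.01 log units; within the scatter), so the two values lie within the scatter of each other.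

Compound 4 `O=C(Nc1cccc(-n2cc(-c3ccncc3)c(-c3ccc(Cl)c(O)c3)n2)c1)Nc1ccc(Cl)c(C(F)(F)F)c1` is not yet measured. It differs from compound 3 by hydrogen in place of methyl on an oxygen on an aromatic ring, the same change that was made from compound 2 to compound 1, and the place of the change is described in the same words in both pairs. Because the earlier step was a 9.0-fold higher number from compound 2 to compound 1 (0.95 log units; beyond the scatter), a step of similar size is expected in this assay from compound 3 to compound 4, namely an estimated 9.0-fold higher number from compound 3 to compound 4 (0.95 log units; beyond the scatter), on the assumption that the chloro on the urea aryl ring, which itself made no difference between compound 2 and compound 3, does not alter the effect. Compound 4 is therefore expected to give about 22000 nM, with a likely range from 8000 nM to 60000 nM.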

Compound 4, concentration for total growth inhibition: 2200 nM
Beside the measured number, compound 4's estimate is 10-fold (1.00 log units) above it; the whole stated range lies above it.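

In this assay, the methoxy to hydroxy change gave a 1.1-fold lower number from compound 3 to compound 4 (0.05 log units; within the scatter), so the step seen on the earlier core did not carry over to this one: the same change on two cores in this assay, a 9.0-fold higher number (0.95 log units; beyond the scatter) from compound 2 to compound 1 and a 1.1-fold lower number (0.05 log units; within the scatter) from compound 3 to compound 4, 10-fold (1.00 log units) apart, beyond the scatter of two such steps. Read the other way round, chloro in place of hydrogen on an aromatic carbon gave a 10-fold lower number from compound 1 to compound 4 (1.01 log units; beyond the scatter), although the same change made no difference on the methoxy core: the same change on two cores in this assay, a 1.0-fold lower number (0.01 log units; within the scatter) from compound 2 to compound 3 and a 10-fold lower number (1.01 log units; beyond the scatter) from compound 1 to compound 4, 10-fold (1.00 log units) apart, beyond the scatter of two such steps. This shows that, among these four compounds, the size of each change depends on the other, so neither step can simply be transferred between the two cores; it does not show why, and a single set of four compounds in one assay sets no rule for the wider series.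

From the compounds shown here alone, it remains open whether a fluoro, a bromo or a methyl in place of that chloro would also leave the methoxy to hydroxy change within the scatter. Also open, going by these compounds, is how an amine or an ethoxy in place of the hydroxy would behave on either core.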